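A Methyl Added to the Phenyl Ring of Compound 1

The source may hold more compounds than are shown below. What is called first, only, known or untested is meant among the compounds shown, and "the series" means these compounds.

Compound 1, `Cn1ncc(-c2nn(C)c3ncnc(N4CCC4)c23)c1-c1ccccc1`, gives 34 mL/min/kg in an ADME assay on microsomes from liver (Homo sapiens) for metabolic stability; a higher number here means faster removal of the compound, a lower number slower removal. Of the three measured compounds it stands lowest: compound 2, `CC(C)Cc1nn(C)c2ncnc(N3Cc4ccccc4C3)c12`, gives 123 mL/min/kg, and compound 3, `CCCOc1cncc2nnc(-c3c[nH]nc3-c3ccc(C(F)(F)F)cc3)n12`, gives 198 mL/min/kg, both gaps well beyond the scatter of repeated measurements. No two of these compounds differ in a single place, so their values say nothing about any one change on its own.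

Compound 4, `Cc1ccc(-c2c(-c3nn(C)c4ncnc(N5CCC5)c34)cnn2C)cc1`, is yet to be measured. It differs from compound 1 in one place: methyl in place of hydrogen on an aromatic carbon. Among the compounds with values here, no measured pair shows how such a change moves this assay, so the expectation rests on compound 1 alone. A modest step upward is expected in this assay, at or just beyond the edge of the scatter, with a real chance of no change at all. Compound 4 is therefore expected to give 50 mL/min/kg, with a range from 25 mL/min/kg to 100 mL/min/kg. The expected step is a 1.5-fold higher number from compound 1 to compound 4 (0.17 log units; within the scatter).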

Compound 4, clearance: 47 mL/min/kg
The estimate for compound 4 lay 1.1-fold (0.03 log units) above the measured number; the range from low to high includes it.
By their numbers in this assay, from the lowest: compounds 1 and 4 (each within the scatter of the next); then compounds 2 and 3 (each within the scatter of the next).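

In this assay, the step from phenyl to 4-methylphenyl gives a 1.4-fold higher number from compound 1 to compound 4 (0.14 log units; within the scatter), so the two compounds cannot be told apart. Within the data shown here, this is the first comparison here that isolates a single change, and it shows that a methyl can stand on this aromatic carbon, para to a large group, with no difference that clears the scatter. Nothing shown here gives a reason for this result.

One methyl at one place is all these compounds cover, so a single step says little about the ring as a whole. Going by these compounds, whether a fluorine, a methoxy group, an amine or a carboxylic acid at the same carbon would also leave the number within the scatter remains open, as does a methyl on another carbon of this ring.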